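Amide nitrogen substituents on the shared core

The source may hold more compounds than are shown below. What is called first, only, known or untested is meant among the compounds shown, and "the series" means these compounds.

Compound 3 `C=CC1=C(C(=O)NC2CCCCC2)C(c2ccc(OC)cc2)OC1` carries cyclohexyl on the amide-type nitrogen. In a functional assay on QGY7701 cells (Homo sapiens) for cytotoxicity, read by MTT assay, with a stated time of 24 h (on this read-out lower numbers stand for stronger inhibition and higher numbers for weaker inhibition), compound 3 gives > 100000 nM, which is a limit of the assay and not a number. Compound 1 `C=CC1=C(C(=O)NC(C)(C)C)C(c2ccc(OC)cc2)OC1`, tert-butyl on the amide-type nitrogen, gives > 100000 nM in this assay, again a limit. Compound 2 `C=CC1=C(C(=O)Nc2ccccc2)C(c2ccc(OC)cc2)OC1`, phenyl on the amide-type nitrogen, gives > 100000 nM in this assay, also a limit. All three sit at the limit of > 100000 nM in this assay, at which 3 of the 3 values shown sit, so the steps a step that the two limits leave unreadable from compound 1 to compound 2, a step that the two limits leave unreadable from compound 1 to compound 3 and a step that the two limits leave unreadable from compound 2 to compound 3 cannot be sized. Compound 4 `C=CC1=C(C(=O)NCc2ccc(Cl)cc2)C(c2ccc(OC)cc2)OC1` differs by 4-chlorobenzyl in place of cyclohexyl on an amide-type nitrogen. Going by the values given here, no measured step bears on a 4-chlorobenzyl group, and the expected step of a number no higher from compound 3 to compound 4 (the limit leaves the size open) therefore has no readable direction. Compound 4 is expected at 100000 nM, within 30000 nM to 300000 nM, most likely again as a limit.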

Compound 4, half-maximal inhibitory concentration: > 100000 nM
Compound 4: only a limit was reported; the forecaster's own chance of this, stated with the estimate: 75%; the middle value sits exactly at the limit.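

No step from compound 4 to compound 1, compound 2 or compound 3 can be read, since all four share one limit: the limit of > 100000 nM in this assay, at which 4 of the 4 values shown sit.

Going by these compounds, whether any amide nitrogen substituent on the shared core gives a measurable value stays open.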